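Halogen swap on a fused-ring urea series

The compounds below may be only part of what the source reports. "The series", "measured", "known", "first", "only" and "open" are said of these compounds alone.

Compound 1, `CC1(C)CC(NC(=O)Nc2ccccc2)c2cc(Cl)ccc2O1`, in a functional assay (aorta) with Rattus norvegicus as the target (a higher number here means that more compound is needed for the effect, a lower number that less compound is needed), gives 7800 nM.
Compound 2, `CC1(C)CC(NC(=O)Nc2ccccc2)c2cc(Br)ccc2O1`, in this assay gives 2300 nM.
Compound 3, `Cc1ccccc1NC(=O)NC1CC(C)(C)Oc2ccc(Cl)cc21`, in this assay gives only a limit of the assay, > 10000 nM.

The two cores differ by methyl in place of hydrogen on an aromatic carbon. That change gives an at least 1.2-fold higher number from compound 1 to compound 3 (0.10 log units; that floor lies within the scatter), with compound 3 resting on (the limit of > 10000 nM in this assay, at which 1 of the 3 values shown sits).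

Within the core of compound 1 the change bromo in place of chloro on an aromatic carbon gives a 3.4-fold lower number from compound 1 to compound 2 (0.53 log units; beyond the scatter), a modest step beyond the scatter.

Compound 4, `Cc1ccccc1NC(=O)NC1CC(C)(C)Oc2ccc(Br)cc21`, is not yet measured. It differs from compound 3 by bromo in place of chloro on an aromatic carbon, the same change as that from compound 1 to compound 2, at the same place word for word. Whether that step carries over from the core of compound 1 to the core of compound 3 rests on a single pair, and compound 3 offers only a limit to start from. The expected step is an at least 2.0-fold lower number from compound 3 to compound 4 (0.30 log units; that floor lies within the scatter), in line with a 3.4-fold lower number from compound 1 to compound 2 (0.53 log units; beyond the scatter). Compound 4 is expected at about 5000 nM, somewhere between 1500 nM and 15000 nM, with a fair chance that only a limit is returned again.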

Compound 4, half-maximal effective concentration: > 30000 nM
Compound 4: no number, only a limit; the forecaster's own chance of this, stated with the estimate: 40%; middle value at least 6.0-fold (0.77 log units) from the limit.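

Compound 3 and compound 4 both stand only as limits of the assay, and the step between them cannot be read, so bromo in place of chloro is neither confirmed nor contradicted on this core, and a 3.4-fold lower number from compound 1 to compound 2 (0.53 log units; beyond the scatter) remains a single pair. Methyl in place of hydrogen on an aromatic carbon, read on the bromo compounds in this assay, gives an at least 13-fold higher number from compound 2 to compound 4 (1.11 log units; beyond the scatter), a large step towards more compound being needed. Set beside the same change on the chloro compounds, this does not show that the methyl step depends on the halogen: the same change on two cores in this assay, an at least 1.2-fold higher number (0.10 log units; that floor lies within the scatter) from compound 1 to compound 3 and an at least 13-fold higher number (1.11 log units; beyond the scatter) from compound 2 to compound 4; the limit leaves it open whether they differ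

The compounds shown leave open how large the methyl step really is on the chloro compounds, and whether any compound carrying that methyl gives a number rather than a limit. They also leave open what an amine or a methoxy group in place of the halogen on the same aromatic carbon would give in this assay.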